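The compounds below may be only part of what the source reports. "The series", "measured", "known", "first", "only" and "open" are said of these compounds alone.

Three compounds share one core, a sugar-bearing bicyclic system carrying a thiophen-2-yl group, and differ only in the group on one aromatic carbon. Compound 1 `COc1ncnc2c1c(-c1cccs1)cn2[C@@H]1O[C@H](CO)[C@@H](O)[C@H]1O` carries a methoxy there, and in a functional assay on HCT-116 cells (Homo sapiens), read by MTT assay, with a stated time of 72 h (on this read-out lower numbers stand for stronger inhibition and higher numbers for weaker inhibition), compound 1 gives 440 nM. Compound 2 `Cc1ncnc2c1c(-c1cccs1)cn2[C@@H]1O[C@H](CO)[C@@H](O)[C@H]1O` carries a methyl instead. In this assay compound 2 reaches only a limit of the assay, > 20000 nM. Compound 3 `CNc1ncnc2c1c(-c1cccs1)cn2[C@@H]1O[C@H](CO)[C@@H](O)[C@H]1O` carries a methylamino. In this assay compound 3 likewise reaches only a limit of the assay, > 20000 nM. So compound 3 stands at the weak end of what is shown: the steps of an at least 45-fold higher number from compound 1 to compound 2 (1.65 log units; beyond the scatter) and an at least 45-fold higher number from compound 1 to compound 3 (1.65 log units; beyond the scatter) are both large, while the comparison of compound 2 with compound 3 cannot be read, since both values sit at the limit of > 20000 nM in this assay, at which 2 of the 3 values shown sit.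

Compound 4 `CNc1ncnc2c1c(-c1ccco1)cn2[C@@H]1O[C@H](CO)[C@@H](O)[C@H]1O` keeps the methylamino of compound 3 and changes the other group: furan-2-yl in place of thiophen-2-yl on an aromatic carbon. Going by the values given here, no measured step touches this swap; the two known steps concern only the methoxy position. Among the compounds with values here, the only guide is that compound 3 already sits at a limit, so the expectation for compound 4 is a number near that limit, with no direction beyond the scatter claimed. The step that the limit leaves unreadable from compound 3 to compound 4 is estimated as essentially flat. Compound 4 is therefore estimated at 25000 nM, with a range from 5000 nM to 100000 nM.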

Compound 4, half-maximal inhibitory concentration: 440 nM
Compound 4: middle estimate off by 57-fold (1.75 log units), on the high side, and the stated range ends above it.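

Going by these compounds alone, the group on the five-membered aromatic ring stayed the same in the earlier compounds, and this result shows that it matters: in this assay, furan-2-yl in place of thiophen-2-yl gives an at least 45-fold lower number from compound 3 to compound 4 (1.65 log units; beyond the scatter). The two groups have the same count of heavy atoms, with oxygen entering where sulfur leaves, so this one change of ring atom is enough to move the methylamino series off the limit of the assay. On these data alone, compound 3 alone might have suggested that methylamino rules out activity on this core, but the result shows that the outcome depends on the group at this place too, and the full size of the step stays unknown because the value of compound 3 is a limit: the limit of > 20000 nM in this assay, at which 2 of the 4 values shown sit.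

The compounds shown leave open whether furan-2-yl has a similar effect alongside methoxy or methyl, as no pair shows this swap with either of those groups. As far as these compounds go, it also remains open how a phenyl ring or a pyrrol-2-yl group would behave at this place, and whether a dimethylamino group could stand in for the methylamino of compound 4.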